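Arylpiperazine series: fluoro on the aromatic ring of compound 2

The source may hold more compounds than are shown below. What is called first, only, known or untested is meant among the compounds shown, and "the series" means these compounds.

Measured so far in an assay on isolated protein for binding affinity to Adrenergic receptor alpha-1 (Rattus norvegicus), read by radioligand binding; a lower number here means a stronger inhibitor, a higher number a weaker inhibitor:
compound 1 `O=C1C2CCCN2C(=O)N1CN1CCN(c2cccc(C(F)(F)F)c2)CC1`: > 1000 nM
compound 2 `O=C1C2CCCN2C(=O)N1CCCN1CCN(c2ccccc2)CC1`: 15.4 nM
compound 3 `O=C1C2CCCN2C(=O)N1CCCN1CCN(c2cccc(C(F)(F)F)c2)CC1`: 109 nM

The value of compound 1 is a limit of this assay, not a number (the limit of > 1000 nM in this assay, at which 1 of the 3 values shown sits). Among the two numbers, compound 2 stands lowest with 15.4 nM; the nearest is compound 3, which in this assay gives 109 nM. The only step shown between these two is a 7.1-fold higher number from compound 2 to compound 3 (0.85 log units; beyond the scatter).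

Compound 4 `O=C1C2CCCN2C(=O)N1CCCN1CCN(c2ccc(F)cc2)CC1` differs from compound 2 in one place: fluoro in place of hydrogen on an aromatic carbon. For the measured compounds named here, the one measured step that bears on this change is the one from compound 2 to compound 3, where a different group was placed on an aromatic carbon of the same ring and the number rose by a 7.1-fold higher number from compound 2 to compound 3 (0.85 log units; beyond the scatter). The group entering here is a single fluorine, smaller than the trifluoromethyl of compound 3, so a smaller move is expected, in the same direction and likely within or only just beyond the scatter.

For compound 4 the expected step is a 1.6-fold higher number from compound 2 to compound 4 (0.21 log units; within the scatter). The estimate for compound 4 in this assay is 25 nM, with a range from 10 nM to 70 nM.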

Compound 4, inhibition constant: 25.2 nM
Beside the measured number, compound 4's estimate is 1.0-fold (0.00 log units) below it, and the stated range covers the measured number.
By their numbers in this assay, from the lowest: compounds 2 and 4 (each within the scatter of the next); then compound 3. At a limit, above all of these: compound 1.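

In this assay, going from phenyl to 4-fluorophenyl gives a 1.6-fold higher number from compound 2 to compound 4 (0.21 log units; within the scatter), so a fluoro on an aromatic carbon, para to a large group, leaves compound 2 and compound 4 indistinguishable in this series. For the compounds shown here, until now the only substituent step on this ring was the trifluoromethyl of compound 3, a 7.1-fold higher number from compound 2 to compound 3 (0.85 log units; beyond the scatter), and that step alone could have suggested that any group on the ring carries a cost; the fluoro result shows that a substituent on this ring does not by itself produce a step beyond the scatter. No measurement shown here bears on why this single fluorine is tolerated.

As far as these compounds go, compound 3 and compound 4 differ in both the group and its place on the ring, and it remains open whether the step to compound 3 follows from the trifluoromethyl itself or from the ring carbon that carries it. From the compounds shown here alone, whether this tolerance extends past a single fluorine also remains open, and chloro, methoxy or an amine on the same ring carbon would test it.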